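A dichlorophenyl isomer of compound 2

The compounds below may be only part of what the source reports. "The series", "measured", "known", "first", "only" and "open" are said of these compounds alone.

In a functional assay on PC-3 cells (Homo sapiens) for antiproliferative activity, read by MTT assay, with a stated time of 48 h (a lower number here means a stronger inhibitor, a higher number a weaker inhibitor), compound 1 `O=C(/C=C/c1ccc(O)cc1)Nc1cc2c(Nc3ccc(Cl)c(Cl)c3)ncnc2s1` gives 300 nM, and compound 2 `O=C(/C=C/c1ccccc1)Nc1cc2c(Nc3ccc(Cl)c(Cl)c3)ncnc2s1` gives 480 nM. Their structures differ by hydrogen in place of hydroxy on an aromatic carbon, and the measured step is a 1.6-fold higher number from compound 1 to compound 2 (0.20 log units; within the scatter). Among the compounds with values here, compound 2 therefore stands level with compound 1, its only measured neighbour, and the two numbers cannot be told apart.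

Compound 3 `O=C(/C=C/c1ccccc1)Nc1cc2c(Nc3cc(Cl)cc(Cl)c3)ncnc2s1` differs from compound 2 in one place, with 3,5-dichlorophenyl in place of 3,4-dichlorophenyl on a nitrogen on an aromatic ring. The two have the same atoms, joined differently. Within the data shown here, the only measured step concerns the hydroxy group and leaves the dichlorophenyl group untouched, so it gives no direct guide to the size of this change. Among the measured compounds shown here, no measured compound carries another dichlorophenyl pattern, so the data set no direction. No change beyond the scatter is expected, and the estimated step, a cautious lean only, is a 1.3-fold higher number from compound 2 to compound 3 (0.10 log units; within the scatter). In this assay, the estimate for compound 3 is 600 nM, with an expected range of 200 nM to 1800 nM.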

Compound 3, half-maximal inhibitory concentration: 390 nM
For compound 3 the middle estimate is 1.5-fold (0.19 log units) above the measured one; measured number inside the range.
By their numbers in this assay, from the lowest: compounds 1, 3 and 2 (each within the scatter of the next).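

In this assay, the step is a 1.2-fold lower number from compound 2 to compound 3 (0.09 log units; within the scatter), so the two dichlorophenyl patterns on this nitrogen cannot be told apart. Within the data shown here, the earlier step concerned only the hydroxy group, whereas this one is the first reading at the aromatic amine position itself, and it shows that exchanging (3,4-dichlorophenyl)amino for (3,5-dichlorophenyl)amino, with the atoms unchanged and only their connection different, leaves the number within the scatter. Nothing shown here on the properties of these two groups bears on this result, and the data offer no account of it.

All three compounds carry two chlorine atoms on this phenyl ring, so the compounds shown leave open what a plain phenyl, a single chlorine, or a different group such as methoxy or trifluoromethyl would do at this position. They also leave open whether the hydroxy group, whose step lies within the scatter alongside 3,4-dichlorophenyl, would read the same way alongside 3,5-dichlorophenyl.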